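Working notes: group exchange on the saturated chain carbon

A few compounds are considered here, and "the series" means these few. Any claim that something is new, unique, unknown or untested is made for them only; others in the source may bear on it.

Measured in an ADME assay on microsomes from liver (Mus musculus) for metabolic stability, read by LC-MS, using NADPH, with stated times of 10 min and 30 min, tested at 1 uM; on this read-out lower numbers stand for slow clearance and higher numbers for fast clearance:
- compound 1 `COC(=O)C1=C(CN2CCCCC2)NC(c2nccs2)=NC1(C)c1ccc(F)cc1`: 88 mL/min/kg
- compound 2 `COC(=O)C1=C(CN2CC3CC2CO3)NC(c2nccs2)=NC1(C)c1ccc(F)cc1`: 84 mL/min/kg
- compound 3 `COC(=O)C1=C(CN2CCOCC2=O)NC(c2nccs2)=NC1(C)c1ccc(F)cc1`: 80 mL/min/kg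

Compound 3, at 80 mL/min/kg, lies within the scatter of both compound 1 and compound 2, so the three values form a single group with no order among them.

The next compound is compound 4 `COC(=O)C1=C(CN2CCC(O)CC2)NC(c2nccs2)=NC1(C)c1ccc(F)cc1`, which differs from compound 3 by one exchange: 4-hydroxypiperidin-1-yl in place of 3-oxomorpholin-4-yl on a saturated chain carbon bound to a double-bonded ring carbon. In words, 4-hydroxypiperidin-1-yl stands in place of 3-oxomorpholin-4-yl on a saturated chain carbon bound to a double-bonded ring carbon.

All three measured steps exchange the group at this same place: a 1.0-fold lower number from compound 1 to compound 2 (0.02 log units; within the scatter), a 1.1-fold lower number from compound 1 to compound 3 (0.04 log units; within the scatter) and a 1.1-fold lower number from compound 2 to compound 3 (0.02 log units; within the scatter). Each of these is small and within the scatter, despite the differing groups. Going by the values given here, no measured compound carries 4-hydroxypiperidin-1-yl, however, so the data cover this exact group only indirectly, and the range is kept wide.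

On these steps, no change beyond the scatter is expected in this assay, and the expected 1.1-fold lower number from compound 3 to compound 4 (0.03 log units; within the scatter) is correspondingly small. For compound 4 the estimated value is 75 mL/min/kg, with an expected range of 48 mL/min/kg to 100 mL/min/kg.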

Compound 4, clearance: 81 mL/min/kg
Estimate against measurement, compound 4: 1.1-fold (0.03 log units) below; low and high end bracket the measured number.
By their numbers in this assay, from the lowest: compounds 3, 4, 2 and 1 (each within the scatter of the next).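

The exchange of 3-oxomorpholin-4-yl for 4-hydroxypiperidin-1-yl, which removes the ring carbonyl and adds a hydrogen-bond donor, leaves this assay without a readable shift, with a 1.0-fold higher number from compound 3 to compound 4 (0.01 log units; within the scatter) and, against the bridged group of 7 heavy atoms, a 1.0-fold lower number from compound 2 to compound 4 (0.02 log units; within the scatter). The series now also holds its smallest exchange, hydroxy in place of hydrogen on a saturated ring carbon, and this gives a 1.1-fold lower number from compound 1 to compound 4 (0.04 log units; within the scatter), so at this place even a change confined to the piperidine ring shows no effect beyond the scatter, and all four compounds still form a single group. No supporting measurement bears on why the read-out stays flat across these groups.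

Still open, as far as these compounds go, is whether any group on a saturated chain carbon bound to a double-bonded ring carbon can move this read-out beyond the scatter, for example a carboxylic acid or a dimethylamino group in place of hydroxy on the piperidine ring. The methyl ester is common to all four compounds, so the compounds shown say nothing about what exchanging it for a carboxamide would do to the number.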